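Biaryl replacing trifluoromethoxyphenyl in a ghrelin receptor series

The source may report more compounds than this note shows. Statements on the series, on what has been measured and on what is new or still open speak of the compounds shown alone.

Measured compounds:
Compound 1: `CC(C)(N)C(=O)N[C@H](COCc1ccccc1Cl)c1nnnn1CCOC(=O)NCCCCO` gives 0.45 nM
Compound 2: `CC(C)(N)C(=O)N[C@H](COCc1cccc(C(F)(F)F)c1)c1nnnn1CCOC(=O)NCCCCO` gives 1.79 nM
Compound 3: `CC(C)(N)C(=O)N[C@H](COCc1ccc(OC(F)(F)F)cc1)c1nnnn1CCOC(=O)NCCCCO` gives 33.2 nM

In a functional assay on cells for inhibition of growth hormone secretagogue receptor type 1 (Homo sapiens), read by FLIPR and calcium flux (a lower number here means that less compound is needed, a higher number that more compound is needed for the effect), compound 3 stands at the highest of the three numbers; the step of a 19-fold higher number from compound 2 to compound 3 (1.27 log units; beyond the scatter) and the step of a 74-fold higher number from compound 1 to compound 3 (1.87 log units; beyond the scatter) both separate it clearly from the other two, which lie within a modest step of each other, a 4.0-fold higher number from compound 1 to compound 2 (0.60 log units; beyond the scatter).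

Compound 4, `CC(C)(N)C(=O)N[C@H](COCc1ccccc1-c1ccccc1)c1nnnn1CCOC(=O)NCCCCO`, is obtained from compound 3 by the change (2-phenylphenyl in place of 4-(trifluoromethoxy)phenyl on a saturated chain carbon bound to an oxygen on a saturated carbon). Both steps that lead into compound 3 bear on this: replacing a 2-chlorophenyl or a 3-(trifluoromethyl)phenyl by the 4-(trifluoromethoxy)phenyl raised the number by a large margin, so removing that group is expected to lower it by a comparable amount in this assay. For the measured compounds named here, the 2-phenylphenyl has no precedent among the measured compounds, so the size of the fall is uncertain. Compound 4 is expected to give about 2.5 nM, within a range of 0.5 nM to 15 nM, an estimated step of a 13-fold lower number from compound 3 to compound 4 (1.12 log units; beyond the scatter).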

Compound 4, half-maximal effective concentration: 0.34 nM
Beside the measured number, compound 4's estimate is 7.4-fold (0.87 log units) above it; measured number outside the range, below it.
By their numbers in this assay, from the lowest: compounds 4 and 1 (each within the scatter of the next); then compound 2; then compound 3.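

In this assay, the large step of a 98-fold lower number from compound 3 to compound 4 (1.99 log units; beyond the scatter) shows that this place, a saturated chain carbon bound to an oxygen on a saturated carbon, can carry two six-membered aromatic rings, and the step of a 5.3-fold lower number from compound 2 to compound 4 (0.72 log units; beyond the scatter) shows that 2-phenylphenyl also compares well with 3-(trifluoromethyl)phenyl. The step of a 1.3-fold lower number from compound 1 to compound 4 (0.12 log units; within the scatter) lies within the scatter, so phenyl in place of chloro on an aromatic carbon gives no difference that can be read. No measurement given here accounts for these steps.

The compounds shown leave open whether the high number of compound 3 goes with the trifluoromethoxy group itself or with where it sits on the ring, a question that 4-chlorophenyl or 4-phenylphenyl would address. They also leave open whether the outer phenyl ring of compound 4 would keep its number when carrying an amine or a carboxylic acid.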